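Chloro to fluoro on the benzyl arm: series notes

The compounds below may be only part of what the source reports. "The series", "measured", "known", "first", "only" and "open" are said of these compounds alone.

Measured compounds:
compound 1, `CC1=C(C(=O)Nc2ccc(F)cc2)C(c2ccc([N+](=O)[O-])cc2)N=C(SCc2ccc(Cl)cc2)N1`, 33.3%
compound 2, `CC1=C(C(=O)Nc2ccc(F)cc2)C(c2ccc([N+](=O)[O-])cc2)N=C(SCc2ccc(F)cc2)N1`, 25.6%
compound 3, `CC1=C(C(=O)Nc2ccc(Br)cc2)C(c2ccc(Cl)cc2Cl)N=C(SCc2ccc(Cl)cc2)N1`, 32.3%

All three numbers come from a functional assay on the whole organism (artery, strain albino) with Rattus norvegicus as the target, with a stated time of 240 min, at a dose of 10 mg/kg by the oral route; on this read-out lower numbers stand for less inhibition and higher numbers for more inhibition at the one dose given (going by the name of the read-out). Compound 1 and compound 2 share a core and differ only by fluoro in place of chloro on an aromatic carbon. That single change gave a number 7.7 percentage points lower from compound 1 to compound 2 (within the scatter), so the two values are not separated by this read-out. Compound 3 carries a different core; the difference between the core of compound 1 and the core of compound 3 is not broken down here. Compound 3 and compound 1 lie within the scatter of each other, as do compound 3 and compound 2.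

Compound 4, `CC1=C(C(=O)Nc2ccc(Br)cc2)C(c2ccc(Cl)cc2Cl)N=C(SCc2ccc(F)cc2)N1`, is not yet measured. It differs from compound 3 by fluoro in place of chloro on an aromatic carbon, the same kind of change as from compound 1 to compound 2, on a 4-chlorobenzyl arm para to a large group in both pairs. In this assay the expected step is a number 7.3 percentage points lower from compound 3 to compound 4 (within the scatter), because the same change gave a number 7.7 percentage points lower from compound 1 to compound 2 (within the scatter) and that step was within the scatter. For compound 4 the estimate is 25%, expected to fall between 13% and 37%.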

Compound 4, a percentage reported as inhibition, in the whole organism at one dose (the size of the read-out at that dose, not a potency): 36.4%
The estimate for compound 4 lay 11.4 percentage points below the measured number; the range from low to high includes it.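

In this assay, fluoro in place of chloro on the benzyl arm gave a number 4.1 percentage points higher from compound 3 to compound 4 (within the scatter), and set beside the earlier step on the other core it reads: the same change on two cores in this assay, a number 7.7 percentage points lower (within the scatter) from compound 1 to compound 2 and a number 4.1 percentage points higher (within the scatter) from compound 3 to compound 4, 11.8 percentage points apart, within the scatter of two such steps. Neither step is resolved by this read-out and the two are not resolved from each other, so the pairs give no sign that the core of compound 1 and the core of compound 3 respond differently to this change. Within the data shown here, this does not show that the change is without effect or that its size is the same on both cores: there are only two pairs, at one dose and one time, and a modest effect or a modest core dependence could lie hidden in the scatter.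

The benzyl arm shown carries only chloro or fluoro, so it remains open whether a methoxy or trifluoromethyl group there would give a step that can be read. Also open, as far as these compounds go, is how an amine or a carboxylic acid in place of the whole benzyl arm would fare.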